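The source may hold more compounds than are shown below. What is called first, only, known or untested is meant among the compounds shown, and "the series" means these compounds.

Measured so far in an ADME assay on BJ cells (Homo sapiens) for cytotoxicity, with a stated time of 72 h; on this read-out lower numbers stand for an effect already at smaller amounts and higher numbers for an effect only at larger amounts of compound:
compound 1 `CCc1ccc(-c2nc3c(c(C)nn3-c3ccccc3)c(-c3ccccc3O)c2C#N)cc1`: > 20000 nM
compound 2 `CCc1ccc(-c2nc3c(c(C)nn3-c3ccccc3)c(-c3ccccc3[N+](=O)[O-])c2C#N)cc1`: > 20000 nM
compound 3 `CCc1ccc(-c2nc3c(c(C)nn3-c3ccccc3)c(-c3ccccc3OC)c2C#N)cc1`: > 20000 nM

All three entries are limits of the assay, not numbers. Compound 1 stands at the limit of > 20000 nM, so it offers no number to step from. The evidence so far comes to one line: the limit of > 20000 nM in this assay, at which 3 of the 3 values shown sit.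

Next in the series is compound 4 `Cc1ccccc1-c1nc2c(c(C)nn2-c2ccccc2)c(-c2ccccc2O)c1C#N`. It keeps the 2-hydroxyphenyl group of compound 1 and carries 2-methylphenyl in place of 4-ethylphenyl on an aromatic carbon, next to the ring nitrogen and ortho to a cyano group: 2-methylphenyl in place of 4-ethylphenyl on an aromatic carbon.

The measured steps bear on this change only indirectly, since none of them alters the 4-ethylphenyl group. They are a step that the two limits leave unreadable from compound 1 to compound 2, a step that the two limits leave unreadable from compound 1 to compound 3 and a step that the two limits leave unreadable from compound 2 to compound 3. No size can be taken from any of them.

For the measured compounds named here, the expectation therefore rests on the shared limit of the three compounds, with no measured step at this place. Compound 1 at > 20000 nM is the reference for it, and that value is a limit. No step beyond the scatter is expected in this assay, and no direction is expected either. The estimated step is a number no higher from compound 1 to compound 4 (the limit leaves the size open). The expected value for compound 4 is 20000 nM, with an estimated range from 10000 nM to 40000 nM.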

Compound 4, half-maximal effective concentration: 21000 nM
For compound 4 the middle estimate is 1.1-fold (0.02 log units) below the measured one, within the range that was stated.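

In this assay no step can be read between compound 4 and compound 1, as compound 1 is recorded only as a limit (> 20000 nM). The compounds shown leave open how large the effect of 2-methylphenyl in place of 4-ethylphenyl is, with no pair carrying numbers on both sides of this change.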